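The source may hold more compounds than are shown below. What is called first, only, known or untested is meant among the compounds shown, and "the series" means these compounds.

Measured so far:
Compound 1 `CCOc1ncccc1-c1c(C)nn(-c2nc(-c3ccc(Cl)c(Cl)c3)c(SC(C)C)s2)c1C(=O)O`: 11000 nM
Compound 2 `Cc1c(-c2cc(Cl)cc(Cl)c2)c(C(=O)O)nn1-c1nc(-c2ccc3nccn3c2)c(SC(C)C)s1`: "not active" (no number reported)
Compound 3 `Cc1c(-c2cc(Cl)cc(Cl)c2)c(C(=O)O)nn1-c1nc(-c2cc(Cl)ccc2F)c(SC(C)C)s1`: 4800 nM

All three compounds were tested in a functional assay on BJAB cells (Homo sapiens) for antiproliferative activity, with a stated time of 4 days; on this read-out higher numbers stand for an effect only at larger amounts of compound and lower numbers for an effect already at smaller amounts. Compound 1 gives 11000 nM. Compound 3 gives 4800 nM. For compound 2 the outcome is reported only as "not active" (no number reported), without a number. Among the two numbers, compound 1 therefore stands highest, so it needs the larger amount to show an effect, and its gap to compound 3 is beyond the scatter of this assay.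

The next compound, compound 4 `Cc1nn(-c2nc(-c3ccc(Cl)c(Cl)c3)c(SC(C)C)s2)c(C(=O)O)c1-c1cncc(C#N)c1`, has not yet been measured. It differs from compound 1 in one place: 5-cyanopyridin-3-yl in place of 2-ethoxypyridin-3-yl on an aromatic carbon. The rest of the shared core is unchanged.

Within the data shown here, no step between two measured compounds of this set mirrors that change, so there is no direct guide to its size. A group of similar size replaces another on the same aromatic carbon, and both carry the same count of hydrogen-bond acceptors. The step from compound 1 to compound 4 is therefore expected to be small, likely within the scatter, which is what a 1.2-fold lower number from compound 1 to compound 4 (0.09 log units; within the scatter) means here. Compound 4 is estimated at 9000 nM, with a range from 3000 nM to 30000 nM.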

Compound 4, half-maximal effective concentration: 20000 nM
Beside the measured number, compound 4's estimate is 2.2-fold (0.35 log units) below it; the range from low to high includes it.
By their numbers in this assay, from the lowest: compound 3; then compounds 1 and 4 (each within the scatter of the next).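

In this assay, exchanging 2-ethoxypyridin-3-yl for 5-cyanopyridin-3-yl gives a 1.8-fold higher number from compound 1 to compound 4 (0.26 log units; within the scatter), the only step shown so far in which a single place changes, here an aromatic carbon of a five-membered aromatic ring with 2 nitrogen. At this carbon, then, a pyridine ring carrying an ethoxy group and one carrying a nitrile cannot be told apart by this read-out, although the two groups differ in what the ring carries and where. Among these compounds, this is a first direct reading for the position, but it covers one exchange only, and nothing measured here accounts for the outcome.

What the compounds shown leave open is how far this position reaches beyond these two substituted pyridine rings: a plain phenyl ring, or a pyridine ring carrying an amine or a longer alkoxy chain, might read the same or quite differently. Compound 2 and compound 3 differ from these compounds in more than one place, so they cannot show whether the same exchange would give a similar step on another version of the shared core.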